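Formyl in place of 2-methylbenzoyl on the cyclohexyl ester

A few compounds are considered here, and "the series" means these few. Any claim that something is new, unique, unknown or untested is made for them only; others in the source may bear on it.

Measured compounds in a functional assay on MCF7 cells (Homo sapiens) for inhibition, read by MTT assay, with a stated time of 72 h; on this read-out higher numbers stand for weaker inhibition and lower numbers for stronger inhibition:
compound 1 `O=C(OC1(C(=O)Nc2ccc([N+](=O)[O-])cc2)CCCCC1)c1ccc(C(F)(F)F)cc1` gives 27.1 nM
compound 2 `Cc1ccccc1C(=O)OC1(C(=O)Nc2ccc([N+](=O)[O-])cc2)CCCCC1` gives 516 nM
compound 3 `CCOC(=O)c1ccccc1C(=O)OC1(C(=O)Nc2ccc([N+](=O)[O-])cc2)CCCCC1` gives 444 nM

Compound 2 gives the highest number of the three, with compound 3 nearest, the pair lying within the scatter of each other, and compound 1 furthest, the difference there being beyond the scatter. The next compound, compound 4 `O=COC1(C(=O)Nc2ccc([N+](=O)[O-])cc2)CCCCC1`, differs from compound 2 in one place: hydrogen in place of 2-methylphenyl on a carbonyl carbon.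

Within the data shown here, two measured steps touch the same carbonyl carbon or its aryl. The step of a 19-fold higher number from compound 1 to compound 2 (1.28 log units; beyond the scatter) is large and swaps one aryl for another. The step of a 1.2-fold lower number from compound 2 to compound 3 (0.07 log units; within the scatter) is within the scatter and changes only a substituent on the aryl. Among the measured compounds shown here, no measured step removes the aryl altogether, so the change to compound 4 is not covered directly.

Because the step of a 19-fold higher number from compound 1 to compound 2 (1.28 log units; beyond the scatter) is large for a mere exchange of aryl groups, removing the aryl entirely is expected to give a step beyond the scatter, towards weaker inhibition, which for compound 4 means an expected step of a 3.9-fold higher number from compound 2 to compound 4 (0.59 log units; beyond the scatter). For the measured compounds named here, the estimate for compound 4 in this assay is 2000 nM, with a range from 400 nM to 10000 nM; the range is wide, since no analogous step has been measured.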

Compound 4, half-maximal inhibitory concentration: 35.4 nM
Compound 4: the middle estimate sits 56-fold (1.75 log units) above what was measured, outside the stated range (below it).
By their numbers in this assay, from the lowest: compounds 1 and 4 (each within the scatter of the next); then compounds 3 and 2 (each within the scatter of the next).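

In this assay, an aryl on this carbonyl carbon proves not to be required for strong inhibition: hydrogen in place of 2-methylphenyl gives a 15-fold lower number from compound 2 to compound 4 (1.16 log units; beyond the scatter), the large step running towards stronger inhibition. Hydrogen in place of 4-(trifluoromethyl)phenyl gives a 1.3-fold higher number from compound 1 to compound 4 (0.12 log units; within the scatter), within the scatter, so compound 1 and compound 4 cannot be told apart in this assay, and the 4-(trifluoromethyl)phenyl group shows no gain over plain hydrogen; the two aryl steps therefore point to 2-methylphenyl as a group that weakens inhibition relative to hydrogen, not to 4-(trifluoromethyl)phenyl as one that strengthens it. No supporting measurement bears on why the position behaves this way.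

Still open, as far as these compounds go, is whether a small acyl such as acetyl, or a longer chain such as hexanoyl, on this carbonyl carbon would stay with compound 4 or move towards compound 2. Also open, from the compounds shown here alone, is whether the carbonyl itself matters, which a hydroxyl or an amine in place of the whole formyl group would test.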